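Swapping Fluorine for Chlorine on a Pyrazole Chalcone Series

A few compounds are considered here, and "the series" means these few. Any claim that something is new, unique, unknown or untested is made for them only; others in the source may bear on it.

Compound 1 `O=C(/C=C\Nc1ccc(O)cc1)c1cn(-c2ccccc2)nc1-c1ccc(F)cc1` and compound 2 `O=C(/C=C\Nc1ccc(O)cc1)c1cn(-c2ccccc2)nc1-c1ccc(Cl)cc1` share one core, while compound 3 `COc1cc(-c2nn(-c3ccccc3)cc2C(=O)/C=C\Nc2ccc(F)cc2)cc(OC)c1OC` and the not yet measured compound 4 `COc1cc(-c2nn(-c3ccccc3)cc2C(=O)/C=C\Nc2ccc(Cl)cc2)cc(OC)c1OC` share another; the difference between the two cores is not broken down here. In a functional assay on A549 cells (Homo sapiens) for antiproliferative activity, read by MTT assay, with a stated time of 48 h (a higher number here means a weaker inhibitor, a lower number a stronger inhibitor), compound 1 gives 1500 nM and compound 2 gives 1910 nM, so that a 1.3-fold higher number from compound 1 to compound 2 (0.10 log units; within the scatter). That change, (chloro in place of fluoro on an aromatic carbon), is therefore close to neutral in this assay. Compound 3 gives 15600 nM, a markedly higher number than either compound 1 or compound 2. Compound 4 carries the same change, (chloro in place of fluoro on an aromatic carbon), at a place described in identical words, on an aromatic carbon of a six-membered aromatic ring of carbon only, para to a large group, though here the wider reading is (4-fluorophenyl)amino to (4-chlorophenyl)amino. Because a 1.3-fold higher number from compound 1 to compound 2 (0.10 log units; within the scatter) stayed within the scatter, a similarly small step is expected, estimated as a 1.2-fold higher number from compound 3 to compound 4 (0.06 log units; within the scatter). Compound 4 is accordingly expected to give about 18000 nM, most likely between 9000 nM and 40000 nM in this assay.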

Compound 4, half-maximal inhibitory concentration: 8670 nM
Estimate against measurement, compound 4: 2.1-fold (0.32 log units) above; measured number below the stated range.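

In this assay, putting chloro in place of fluoro on the aromatic carbon gives a 1.8-fold lower number from compound 3 to compound 4 (0.26 log units; within the scatter), so on this second core the step also stays within the ordinary scatter of the measurement. Set side by side, the steps on the two cores cannot be told apart: the same change on two cores in this assay, a 1.3-fold higher number (0.10 log units; within the scatter) from compound 1 to compound 2 and a 1.8-fold lower number (0.26 log units; within the scatter) from compound 3 to compound 4, 2.3-fold (0.36 log units) apart, within the scatter of two such steps. For these two pairs, then, the change carries from one core to the other with no difference the data can resolve, but two pairs make no rule for the whole series, and they cannot show why the step is small or whether a real difference lies hidden inside the scatter.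

The compounds shown carry only fluoro or chloro on the aromatic carbon that changes, so it remains open how a bromo, methoxy or trifluoromethyl group would behave there. On these data alone, it is also open whether an amine or a carboxylic acid at that place would give a step beyond the scatter on either core.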